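The compounds below may be only part of what the source reports. "The series", "measured", "known", "first", "only" and "open" are said of these compounds alone.

Working notes on the series, read out in an in vitro ADME assay on microsomes from liver (Rattus norvegicus) for metabolic stability, read by LC-MS, tested at 1 uM; a lower number here means slower removal, a higher number faster removal of the compound. Compound 1 `CN(C)S(=O)(=O)c1ccc(F)c(C#Cc2cc(Cl)ccc2OCC(=O)O)c1` gives < 10 mL.min-1.g-1, which is a limit of the assay and not a number. Among the measured compounds shown here, compound 2 `Cc1ccc(S(=O)(=O)N2CCOCC2)cc1C#Cc1cc(Cl)ccc1OCC(=O)O` gives 10 mL.min-1.g-1, the only true number so far, so its place cannot be ranked against compound 1.

The next step leads to compound 3 `Cc1ccc(S(C)(=O)=O)cc1C#Cc1cc(Cl)ccc1OCC(=O)O`, with methyl in place of morpholin-4-yl on a sulfonyl sulfur. The same difference, cut one bond further out, reads (morpholin-4-yl)sulfonyl to methylsulfonyl. For the measured compounds named here, no measured pair shows this change, so the expectation has little to rest on beyond compound 2 at 10 mL.min-1.g-1 in this assay.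

No shift beyond the scatter is expected, and the estimated step is a 1.3-fold lower number from compound 2 to compound 3 (0.10 log units; within the scatter). A result reported only as a limit is a real possibility for this compound. For compound 3 the estimated value is 8 mL.min-1.g-1, with an expected range from 4 mL.min-1.g-1 to 16 mL.min-1.g-1.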

Compound 3, intrinsic clearance in microsomes: 18 mL.min-1.g-1
Beside the measured number, compound 3's estimate is 2.3-fold (0.35 log units) below it; the whole stated range lies below it.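

Among the compounds shown here, on a sulfonyl sulfur, methyl in place of morpholin-4-yl gives a 1.8-fold higher number from compound 2 to compound 3 (0.26 log units; within the scatter) in this assay, and this is the first step that can be read as a number. The six-membered non-aromatic ring can therefore leave this position, with methyl entering in its place, without a shift beyond the scatter in this read-out, so compound 2 and compound 3 cannot be ordered on this pair alone. Compound 1 is reported only as a limit of the assay, so the low end of the scale stays unresolved in the series: the limit of < 10 mL.min-1.g-1 in this assay, at which 1 of the 3 values shown sits.

For the compounds shown here, compound 1 differs from compound 2 and from compound 3 in more than one place, so steps to it cannot be read, and the single pair says nothing about how other groups would behave on this sulfonyl sulfur. Still open, on these data alone, is whether a simple amino group, or a longer chain such as ethyl or propyl, on the same sulfur would stay within the scatter of compound 3 in this assay or move beyond it.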